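Aryl replacement at the amine-bound chain carbon: compound 4

This account rests on a few compounds, and the source may have more. Where it says the series, first, only, none or still open, it means among the compounds named here.

Measured so far:
Compound 1 `CCCN(Cc1ccc(OCCn2c(=O)ccn(C)c2=O)c(C)c1)C(CC(=O)O)c1ccc(Cl)cc1` gives 123 nM in an assay on CHO cells for displacement of a labelled ligand from C-X-C chemokine receptor type 3 (Homo sapiens), with a stated time of 60 min; on this read-out higher numbers stand for weaker inhibition and lower numbers for stronger inhibition.
Compound 2 `CCCN(Cc1ccc(OCCn2c(=O)ccn(C)c2=O)c(OC)c1)C(CC(=O)O)c1ccc(Cl)cc1` gives 132 nM.
Compound 3 `CCCCN(Cc1ccc(OCCn2c(=O)ccn(C)c2=O)c(OC)c1)C(CC(=O)O)c1ccc(Cl)cc1` gives 69 nM.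

Compound 2 holds the highest of the three numbers, but neither gap reaches beyond the scatter: a 1.1-fold higher number from compound 1 to compound 2 (0.03 log units; within the scatter), and a 1.9-fold lower number from compound 2 to compound 3 (0.28 log units; within the scatter). Going by the values given here, the series so far shows no step beyond the scatter at all.

Compound 4 `CCCN(Cc1ccc(OCCn2c(=O)ccn(C)c2=O)c(OC)c1)C(CC(=O)O)c1ccc2c(c1)CCO2` differs from compound 2 by a group of 9 heavy atoms (8 carbon, 1 oxygen; one five-membered non-aromatic ring with 1 hetero atom, one six-membered aromatic ring of carbon only) in place of a group of 7 heavy atoms (6 carbon, 1 chlorine; one six-membered aromatic ring of carbon only), on a saturated chain carbon bound to an amine nitrogen and a saturated chain carbon. Among the compounds with values here, no measured step touches this part of the shared core; the two steps above concern an aromatic carbon and a chain carbon three bonds from the amine nitrogen. Nothing here predicts a step beyond the scatter, so the expectation is roughly unchanged with wide uncertainty. Compound 4 is estimated at 150 nM, range 50 nM to 450 nM. The expected step is a 1.1-fold higher number from compound 2 to compound 4 (0.06 log units; within the scatter).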

Compound 4, half-maximal inhibitory concentration: 154 nM
Compound 4: the middle estimate sits 1.0-fold (0.01 log units) below what was measured, and the stated range covers the measured number.
By their numbers in this assay, from the lowest: compounds 3, 1, 2 and 4 (each within the scatter of the next, the first and the last beyond it).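

In this assay, the carbon bound to an amine nitrogen and a saturated chain carbon accepts a change of aryl group, with 4-chlorophenyl replaced by the larger oxygen-containing group for a 1.2-fold higher number from compound 2 to compound 4 (0.07 log units; within the scatter) in this single pair. Going by these compounds alone, this is the first step at this position, and it shows that chlorine is not required in this pair to stay within the scatter. No available evidence bears on this result.

Open, from the compounds shown here alone, is how a pyridine ring or unsubstituted phenyl would read at this carbon. Also open, going by these compounds, is whether a butyl chain on the amine nitrogen would read differently alongside the new group.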